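The source may report more compounds than this note shows. Statements on the series, on what has been measured and on what is new or still open speak of the compounds shown alone.

Measured so far in an ADME assay for pharmacokinetics; a higher number here means that the compound lasts longer, a lower number that the compound disappears faster:
- compound 1 `NC(=O)c1ncn2c(=O)n(-c3ccccc3)nnc12`: 0.383 h
- compound 2 `NC(=O)c1ncn2c(=O)n(-c3ccc(Cl)cc3)nnc12`: 0.105 h

For the measured compounds named here, compound 2 holds the lower of the two numbers, and compound 1, the only other measured compound, lies beyond the scatter from it. The next compound is compound 3 `COc1ccc(-n2nnc3c(C(N)=O)ncn3c2=O)cc1`, not yet measured. The change is methoxy in place of chloro on an aromatic carbon and amounts to methoxy in place of chloro on an aromatic carbon, para to a large group.

Going by the values given here, the only measured step that bears on this is a 3.6-fold lower number from compound 1 to compound 2 (0.56 log units; beyond the scatter) and it is a modest one, for chloro in place of hydrogen on an aromatic carbon. Among the compounds with values here, no compound with methoxy has been measured, so the size of the new step rests on that single comparison. Within the data shown here, with the chloro leaving, a rise in this assay of similar size is expected because a 3.6-fold lower number from compound 1 to compound 2 (0.56 log units; beyond the scatter) is the only guide, and the uncertainty is wide. The expected step is a 3.8-fold higher number from compound 2 to compound 3 (0.58 log units; beyond the scatter) in this series. Compound 3 is estimated at 0.4 h (expected range 0.15 h to 1 h).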

Compound 3, half-life: 1.15 h
Beside the measured number, compound 3's estimate is 2.9-fold (0.46 log units) below it; the measured number lies above the stated range.
By their numbers in this assay, from the lowest: compound 2; then compound 1; then compound 3.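

In this assay, the position para to a large group now shows a change of direction: a 3.0-fold higher number from compound 1 to compound 3 (0.48 log units; beyond the scatter) with methoxy in place of hydrogen, against a 3.6-fold lower number from compound 1 to compound 2 (0.56 log units; beyond the scatter) with chloro in place of hydrogen. The two substituents therefore fall on opposite sides of the hydrogen compound, and the exchange of chloro for methoxy gives an 11-fold higher number from compound 2 to compound 3 (1.04 log units; beyond the scatter), the largest of the three steps at this place, so the result at this position depends strongly on which group is present and cannot be read from the chloro step alone. No measurement in hand explains why the two groups move the half-life in opposite directions.

Going by these compounds, whether the rise is particular to methoxy or also appears with fluoro, an amine or a longer ether chain such as ethoxy at this same place remains open. Also open, on these data alone, is whether methoxy gives a similar rise elsewhere on the six-membered aromatic ring, since all three compounds carry their variation at the one place.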